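The source may hold more compounds than are shown below. What is called first, only, known or untested is meant among the compounds shown, and "the series" means these compounds.

Measured in an assay on isolated protein for inhibition of Nicotinamide phosphoribosyltransferase (Homo sapiens), read by fluorescence, with stated times of 5 min and 15 min; a higher number here means a weaker inhibitor, a lower number a stronger inhibitor:
- compound 1 `Nc1ccccc1NC(=O)c1ccc(NC(=S)NCc2cncc(Br)c2)cc1`: a limit only, > 2000 nM
- compound 2 `Nc1ccccc1NC(=O)c1ccc(NC(=O)NCc2ccc(Cl)nc2)cc1`: a limit only, > 2000 nM

Compound 1 stands at a limit of this assay, not at a number. Among the measured compounds shown here, both values shown sit at that same limit (the limit of > 2000 nM in this assay, at which 2 of the 2 values shown sit), so no ranking among the measured compounds is possible and no pair differing in one place gives a measured step. Compound 3 `Cc1ccc(CNC(=S)Nc2ccc(C(=O)Nc3ccccc3N)cc2)cn1` differs from compound 1 by 6-methylpyridin-3-yl in place of 5-bromopyridin-3-yl on a saturated chain carbon bound to an amide-type nitrogen. For the measured compounds named here, no measured step guides this change, so nothing beyond the scatter is expected from compound 1 to compound 3, and the step that the limit leaves unreadable from compound 1 to compound 3 is expected to be small. Compound 3 is expected at 3000 nM, with a range of 800 nM to 12000 nM, most likely again reported only as a limit.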

Compound 3, half-maximal inhibitory concentration: > 2000 nM
Compound 3 was reported as a limit; the forecaster's own chance of this, stated with the estimate: 70%; the middle value lies beyond the limit too.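

Among the compounds shown here, compound 1 and compound 3 both stand at a limit, so no step between them can be read: the limit of > 2000 nM in this assay, at which 3 of the 3 values shown sit.
From the compounds shown here alone, whether any change to the shared core gives a measurable value in this assay remains open.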